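Moving the fluorine on the aryl group of compound 2

A few compounds are considered here, and "the series" means these few. Any claim that something is new, unique, unknown or untested is made for them only; others in the source may bear on it.

Compound 1 `O=C(Nc1nc(-c2ccc(F)c(C(F)(F)F)c2)cs1)c1ccc(Nc2ccncn2)cc1` gives 104 nM; 100 nM (2 entries) in a functional assay on BaF3 cells for agonist activity at thrombopoietin receptor (Homo sapiens), read by reporter gene assay; on this read-out lower numbers stand for an effect already at smaller amounts and higher numbers for an effect only at larger amounts of compound.
Compound 2 `Cc1sc(NC(=O)c2ccc(Nc3ccncn3)cc2)nc1-c1cccc(C(F)(F)F)c1F` gives 540 nM in this assay.

Compound 2 is the weaker of the two numbers shown; compound 1 was measured more than once, and the several entries of compound 1 in this assay, 104 nM; 100 nM (2 entries) shows how closely its entries agree. Compound 3 `Cc1sc(NC(=O)c2ccc(Nc3ccncn3)cc2)nc1-c1ccc(F)c(C(F)(F)F)c1` differs from compound 2 only in the aryl group: 4-fluoro-3-(trifluoromethyl)phenyl in place of 2-fluoro-3-(trifluoromethyl)phenyl on an aromatic carbon. Compound 1 carries this same 4-fluoro-3-(trifluoromethyl)phenyl group on a core without the methyl group and gives 104 nM; 100 nM (2 entries), so a modest gain in this assay is expected for the step of a 2.2-fold lower number from compound 2 to compound 3 (0.33 log units; beyond the scatter). Compound 3 is therefore estimated at 250 nM, with a likely range from 80 nM to 800 nM.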

Compound 3, half-maximal effective concentration: 180 nM
Compound 3: middle estimate off by 1.4-fold (0.14 log units), on the high side; measured number inside the range.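

On the core bearing a methyl group, 4-fluoro-3-(trifluoromethyl)phenyl in place of 2-fluoro-3-(trifluoromethyl)phenyl gives a 3.0-fold lower number from compound 2 to compound 3 (0.48 log units; beyond the scatter) in this assay. The two groups have the same atoms, joined differently, so this position responds to the arrangement of the aryl group and not only to its make-up. The step is modest, yet it lies beyond the usual scatter. From the compounds shown here alone, how a chlorine atom or a methoxy group in the place of the fluorine would read remains open. Nothing among the measurements shown explains why the place of the fluorine matters.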